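Substituent on the ring nitrogen of the shared core

The source may hold more compounds than are shown below. What is called first, only, known or untested is meant among the compounds shown, and "the series" means these compounds.

Measured so far:
- compound 1 `O=C(O)Cn1nc(CC(=O)Nc2ccc(OC(F)(F)F)c(Cl)c2)c2ccccc2c1=O`: 389 nM
- compound 2 `O=C(Cc1nn(C2CCNC2)c(=O)c2ccccc12)Nc1ccc(OC(F)(F)F)c(Cl)c1`: 94 nM
- compound 3 `C[C@@H](C(=O)O)c1nn(Cc2cn3cc(OCC4CC4)c(Cl)cc3n2)c2ccccc2c1=O`: 24 nM

In a functional assay on CHO cells for antagonist activity at sphingosine 1-phosphate receptor 2 (Homo sapiens), read by calcium flux (on this read-out lower numbers stand for stronger inhibition and higher numbers for weaker inhibition), compound 2 gives 94 nM, the second highest of the three numbers shown. Compound 3 gives 24 nM, and the step from compound 3 to compound 2 is beyond the scatter. Compound 1 gives 389 nM, and that step is beyond the scatter as well.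

Compound 4 `CCn1nc(CC(=O)Nc2ccc(OC(F)(F)F)c(Cl)c2)c2ccccc2c1=O` differs from compound 2 in one place: ethyl in place of pyrrolidin-3-yl on an aromatic nitrogen.

For the measured compounds named here, only one measured step touches this position: a 4.1-fold lower number from compound 1 to compound 2 (0.62 log units; beyond the scatter). It shows that the group on this nitrogen can move the number by a modest amount, but neither measured pair involves ethyl, and compound 3 carries a different core and does not bear on the change. The direction of the step to compound 4 therefore rests on the weak ground that compound 2 is the only measured point with this group. On balance a modest rise in the number is expected, with wide uncertainty, which would be read as a 2.1-fold higher number from compound 2 to compound 4 (0.33 log units; beyond the scatter).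

Compound 4 is estimated at 200 nM in this assay, with a range from 60 nM to 650 nM.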

Compound 4, half-maximal inhibitory concentration in the sphingosine 1-phosphate receptor 2 assay: 199 nM
Compound 4: middle estimate off by 1.0-fold (0.00 log units), on the high side; the range from low to high includes it.
By their numbers in the sphingosine 1-phosphate receptor 2 assay, from the lowest: compound 3; then compound 2; then compounds 4 and 1 (each within the scatter of the next).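

In the sphingosine 1-phosphate receptor 2 assay, ethyl in place of pyrrolidin-3-yl gives a 2.1-fold higher number from compound 2 to compound 4 (0.33 log units; beyond the scatter), so losing the ring and the hydrogen-bond donor and acceptor counted on that group changes the number only modestly. Methyl in place of carboxy on the saturated chain carbon bound to the aromatic nitrogen gives a 2.0-fold lower number from compound 1 to compound 4 (0.29 log units; within the scatter), so this read-out does not separate the carboxymethyl group of compound 1 from the ethyl group of compound 4, and of the three groups on this nitrogen only pyrrolidin-3-yl stands apart from both others. In a physicochemical assay for lipophilicity, at pH 7.4 (a higher number here means a more lipophilic compound, a lower number a more polar compound), compound 2 gives 3.03 and compound 4 gives 5.42, so the same change makes compound 4 far more lipophilic, yet this brings no lower number in the sphingosine 1-phosphate receptor 2 assay: the measured distribution coefficient of compound 2, 3.03, and of compound 4, 5.42, a number 2.39 log units higher (beyond the scatter)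

Going by these compounds, it remains open whether the lower number of compound 2 goes with its ring, its amine nitrogen or its size, as ethyl differs from pyrrolidin-3-yl in all of these at once. An open-chain aminoethyl group, a cyclopentyl ring without the nitrogen or a longer alkyl chain on the same ring nitrogen would begin to pull these apart.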